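Moving from Chloro to Cyano on the Benzoyl Ring

The source may report more compounds than this note shows. Statements on the series, on what has been measured and on what is new or still open speak of the compounds shown alone.

Compound 1 `CC(C)(C)N(NC(=O)c1ccccc1F)C(=O)c1ccccc1Cl` gives 51.3 nM in an assay on cells for agonist activity at ecdysone receptor (Bombyx mori), read by a luciferase reporter, with a stated time of 24 h; on this read-out lower numbers stand for an effect already at smaller amounts and higher numbers for an effect only at larger amounts of compound.
Compound 2 `CC(C)(C)N(NC(=O)c1ccccc1I)C(=O)c1ccccc1Cl` gives 1290 nM in this assay.
Compound 3 `CC(C)(C)N(NC(=O)c1cccc(Cl)c1)C(=O)c1ccccc1Cl` gives 155 nM in this assay.

Compound 3 stands second highest of the three numbers in this assay: compound 1 lies lower by a 3.0-fold higher number from compound 1 to compound 3 (0.48 log units; beyond the scatter), while compound 2 lies higher by an 8.3-fold lower number from compound 2 to compound 3 (0.92 log units; beyond the scatter). Compound 4 `CC(C)(C)N(NC(=O)c1cccc(C#N)c1)C(=O)c1ccccc1Cl` keeps the whole core of compound 3 and differs in one place only: cyano in place of chloro on an aromatic carbon.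

Going by the values given here, none of the measured steps involves a cyano group. The steps that exist swap one halogen for another on the same ring position, a 25-fold higher number from compound 1 to compound 2 (1.40 log units; beyond the scatter), or move a halogen from one ring position to another, a 3.0-fold higher number from compound 1 to compound 3 (0.48 log units; beyond the scatter) and an 8.3-fold lower number from compound 2 to compound 3 (0.92 log units; beyond the scatter). They show that the ring attached to the hydrazide carbonyl is sensitive to what sits on it, but they give no direct guide for a cyano in place of a chloro at a position that is otherwise held fixed. The expectation for compound 4 is therefore a step of a 1.6-fold higher number from compound 3 to compound 4 (0.21 log units; within the scatter), within or close to the scatter, with a wide range to reflect the lack of a matching precedent. Compound 4 is estimated at 250 nM, between 80 nM and 800 nM.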

Compound 4, half-maximal effective concentration: 955 nM
For compound 4 the middle estimate is 3.8-fold (0.58 log units) below the measured one; the whole stated range lies below it.
By their numbers in this assay, from the lowest: compound 1; then compound 3; then compounds 4 and 2 (each within the scatter of the next).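

At the place on the ring where compound 3 carries its chloro, the two groups are not interchangeable: in this assay the swap to cyano gives a 6.2-fold higher number from compound 3 to compound 4 (0.79 log units; beyond the scatter) even though the change adds no ring and no net charge. The comparison with the other compounds is uneven. A step of a 1.4-fold lower number from compound 2 to compound 4 (0.13 log units; within the scatter) leaves no real difference between a 3-cyanophenyl and a 2-iodophenyl group, whereas a step of a 19-fold higher number from compound 1 to compound 4 (1.27 log units; beyond the scatter) sets the 3-cyanophenyl group far from the 2-fluorophenyl group, which needs much less compound for the same effect. No measurement in hand gives a reason for the step from chloro to cyano.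

Going by these compounds, with only chloro and cyano compared at this place, it stays open whether an amine, a carboxylic acid or a methoxy group there would give a number nearer that of compound 3 or that of compound 4. Also open, on these data alone, is whether putting cyano in place of the fluoro of compound 1, with the rest of the structure unchanged, would bring a step of similar size.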